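Aryl ketone succinimides: methyl to chloro exchange

The compounds below may be only part of what the source reports. "The series", "measured", "known", "first", "only" and "open" are said of these compounds alone.

Measured so far:
compound 1 `O=C1CCOCC1C1CC(=O)N(c2ccccc2)C1=O`: 26800 nM
compound 2 `Cc1ccc(C(=O)CC2CC(=O)N(c3ccc(S(N)(=O)=O)cc3)C2=O)cc1`: 860 nM

Both numbers come from an assay on cells (1-87 tumor cell line) for inhibition of Polyunsaturated fatty acid 5-lipoxygenase (Homo sapiens), with a stated time of 5 min; on this read-out lower numbers stand for stronger inhibition and higher numbers for weaker inhibition. Among the measured compounds shown here, of the two, compound 2 stands lowest; its only neighbour, compound 1, sits far above it, and that gap lies well beyond the usual scatter. Compound 1 also carries a different core and no sulfonamide-bearing ring, so the pair says nothing about any single change.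

Compound 3 `NS(=O)(=O)c1ccc(N2C(=O)CC(CC(=O)c3ccc(Cl)cc3)C2=O)cc1` keeps the whole of compound 2 apart from one exchange: chloro in place of methyl on an aromatic carbon — chloro in place of methyl on an aromatic carbon of a six-membered aromatic ring of carbon only, para to a large group. No measured pair shows this change, so there is no shown step to lean on. The working expectation is a step of a 1.1-fold lower number from compound 2 to compound 3 (0.06 log units; within the scatter), which is expected to fall within the scatter rather than move the number in a clear direction. On that basis compound 3 is estimated at 750 nM, with a range from 250 nM to 2500 nM; the measurement will settle it.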

Compound 3, half-maximal inhibitory concentration: 12600 nM
Estimate against measurement, compound 3: 17-fold (1.23 log units) below; measured number above the stated range.
By their numbers in this assay, from the lowest: compound 2; then compound 3; then compound 1.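

In this assay the exchange of 4-methylphenyl for 4-chlorophenyl on the aryl ketone gives a 15-fold higher number from compound 2 to compound 3 (1.17 log units; beyond the scatter) and so shows that this position responds strongly, even though one heavy atom simply replaces another and no ring, hydrogen-bond donor, hydrogen-bond acceptor or net charge enters or leaves. Compound 1 and compound 2 differ in more than one place and could tie the number to no single site, whereas this pair ties a large step to the aromatic carbon para to a large group, with methyl giving the lower number of the two groups compared there. Nothing measured on these compounds bears on the origin of this step.

A single exchange cannot tell whether the rise is particular to chloro or follows any departure from methyl; hydrogen, fluoro, methoxy, ethyl or an amine on the same carbon would separate those readings. The sulfonamide also never changes alone in the compounds shown, so its own share in the number remains open, as does whether the methyl to chloro step would keep its size without it.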